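A few compounds are considered here, and "the series" means these few. Any claim that something is new, unique, unknown or untested is made for them only; others in the source may bear on it.

In a functional assay on QG-56 cells (Homo sapiens) for antiproliferative activity (a higher number here means a weaker inhibitor, a lower number a stronger inhibitor), the series stands as follows:
compound 1 `Cn1cncc1C(O)(c1ccc(C#N)cc1)c1cc2cc([N+](=O)[O-])cc(-c3ccccc3F)c2o1` gives 89.5 nM
compound 2 `Cn1cncc1C(O)(c1ccc(I)cc1)c1cc2cc([N+](=O)[O-])cc(-c3ccccc3)c2o1` gives > 10000 nM as a limit of the assay, not a number
compound 3 `COC(=O)c1cc(-c2cccc(OC)c2)c2oc(C(O)(c3ccc(C#N)cc3)c3cncn3C)cc2c1` gives 36.3 nM

Of the two actual numbers, compound 1 has the higher value, and compound 3 lies lower by a gap beyond the usual scatter. Compound 2 stands at the limit of > 10000 nM in this assay, at which 1 of the 3 values shown sits, and offers no number for comparison.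

Next to be read is compound 4 `Cn1cncc1C(O)(c1ccc(C#N)cc1)c1cc2cc([N+](=O)[O-])cc(-c3cccc(F)c3)c2o1` with the same atoms as compound 1, joined differently. The difference is 3-fluorophenyl in place of 2-fluorophenyl on an aromatic carbon with 3-fluorophenyl in place of 2-fluorophenyl on an aromatic carbon.

For the measured compounds named here, no two measured compounds differ in one place only, so the series gives no direct guide to this move, and the range has to stay wide. The counted features do not change, and compound 1 at 89.5 nM is the natural anchor, so in this assay no shift beyond the scatter is expected. The expected step of a 1.1-fold lower number from compound 1 to compound 4 (0.05 log units; within the scatter) is small, with no firm direction. Compound 4 is estimated at 80 nM with an expected range of 25 nM to 300 nM for now.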

Compound 4, half-maximal inhibitory concentration: 145 nM
Compound 4: the middle estimate sits 1.8-fold (0.26 log units) below what was measured, within the range that was stated.
By their numbers in this assay, from the lowest: compound 3; then compounds 1 and 4 (each within the scatter of the next). At a limit, above all of these: compound 2.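

In this assay, shifting the fluorine from 2-fluorophenyl to 3-fluorophenyl gives a 1.6-fold higher number from compound 1 to compound 4 (0.21 log units; within the scatter), the only single-place step shown in the series. At this position, on an aromatic carbon meta to a nitro group, the two fluorophenyl isomers therefore cannot be told apart, and no order can be set between the two compounds. Nothing measured here bears on what lies behind this step.

Going by these compounds, the step covers only these two fluorophenyl isomers, so it remains open whether an amine or a carboxylic acid on that phenyl ring, or a morpholine in place of the ring, would keep activity at the level of compound 1. On these data alone, the separate contributions of the nitrile and the nitro group also remain open, since compound 2 and compound 3 each differ from compound 1 in more than one place and so give no clean reading of either group.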